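The source may report more compounds than this note shows. Statements on the series, on what has been measured and on what is new or still open speak of the compounds shown alone.

Of the compounds shown here, three have been tested in a functional assay, read by spectrophotometry, with a stated time of 1 h; a higher number here means a weaker inhibitor, a lower number a stronger inhibitor. For the measured compounds named here, compound 1 `Nc1ccccc1/N=C\c1cc(=O)oc2cc(OCc3ccccc3)ccc12` gives 34600 nM, while compound 2 `O=c1cc(/C=N\Nc2ccccc2)c2ccc(OCc3ccccc3)cc2o1` gives 455000 nM, the one measured single change being a 13-fold higher number from compound 1 to compound 2 (1.12 log units; beyond the scatter). Compound 3 `N/N=C\c1cc(=O)oc2cc(OCc3ccccc3)ccc12` is reported in this assay only as "not active" (no number reported), so no number marks where it stands, other than weaker than compound 1 and compound 2. The next compound, compound 4 `O=c1cc(-c2nc3ccccc3[nH]2)c2ccc(OCc3ccccc3)cc2o1`, arises from compound 3 through (a group of 9 heavy atoms (7 carbon, 2 nitrogen; one five-membered aromatic ring with 2 hetero atoms, one six-membered aromatic ring of carbon only) in place of a group of 3 heavy atoms (1 carbon, 2 nitrogen; no ring), on an aromatic carbon). Going by the values given here, no measured step touches this position; the one step at hand, in this assay from compound 1 to compound 2, concerns a different part of the shared core and shows only that a single change can move the number a long way. The value of compound 4 is therefore estimated with wide bounds at 100000 nM, between 10000 nM and 1000000 nM.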

Compound 4, half-maximal inhibitory concentration: "not active" (no number reported)
The entry for compound 4 holds no number, so the estimate cannot be set against anything.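

Compound 3 and compound 4 are both reported only as "not active" in this assay, so no step can be read between them, and no other data bear on this result. As far as these compounds go, how far the 1H-benzimidazol-2-yl group moves the number from that of compound 3 remains open.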